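Furan for Thiophene on a Shared Nucleoside Core

The source may hold more compounds than are shown below. What is called first, only, known or untested is meant among the compounds shown, and "the series" means these compounds.

Compound 1 `CNc1ncnc2c1c(-c1ccoc1)cn2[C@@H]1O[C@H](CO)[C@@H](O)[C@H]1O`: 96300 nM
Compound 2 `COc1ncnc2c1c(-c1ccoc1)cn2[C@@H]1O[C@H](CO)[C@@H](O)[C@H]1O`: 28800 nM
Compound 3 `CSc1ncnc2c1c(-c1ccsc1)cn2[C@@H]1O[C@H](CO)[C@@H](O)[C@H]1O`: 95800 nM

In an ADME assay on BJ cells (Homo sapiens), read by MTT assay, with a stated time of 72 h (a lower number here means a stronger inhibitor, a higher number a weaker inhibitor), compound 3 gives 95800 nM, the second highest of the three numbers: it sits with compound 1 within the scatter and differs from compound 2 beyond it. Compound 4 `CSc1ncnc2c1c(-c1ccoc1)cn2[C@@H]1O[C@H](CO)[C@@H](O)[C@H]1O` differs from compound 3 by furan-3-yl in place of thiophen-3-yl on an aromatic carbon. Within the data shown here, the one measured step, a 3.3-fold lower number from compound 1 to compound 2 (0.52 log units; beyond the scatter), concerns a different group and does not bear directly on this exchange, and no measured pair sets furan-3-yl against thiophen-3-yl. The exchange is therefore expected to bring no change beyond the scatter, a 1.2-fold lower number from compound 3 to compound 4 (0.08 log units; within the scatter). Compound 4 is expected to give 80000 nM, within 30000 nM to 200000 nM.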

Compound 4, half-maximal inhibitory concentration: 98800 nM
Compound 4: the middle estimate sits 1.2-fold (0.09 log units) below what was measured; measured number inside the range.
By their numbers in this assay, from the lowest: compound 2; then compounds 3, 1 and 4 (each within the scatter of the next).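

In this assay the step of a 1.0-fold higher number from compound 3 to compound 4 (0.01 log units; within the scatter) for furan-3-yl in place of thiophen-3-yl shows that, with methylsulfanyl on the shared core, this aromatic carbon does not separate the two rings. With furan-3-yl held fixed, the step of a 3.4-fold higher number from compound 2 to compound 4 (0.54 log units; beyond the scatter) for methylsulfanyl in place of methoxy lies beyond the scatter, while the step of a 1.0-fold higher number from compound 1 to compound 4 (0.01 log units; within the scatter) for methylsulfanyl in place of methylamino lies within it. Nothing measured here accounts for these numbers. Still open, on these data alone, is whether the two rings also match when methoxy replaces methylsulfanyl, and how a phenyl group or an aminomethyl group would read at this carbon.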